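The source may hold more compounds than are shown below. What is called first, only, known or untested is meant among the compounds shown, and "the series" means these compounds.

Compound 1 `CCCCC[Se]c1nc([Se]CCCCC)c2ccccc2n1` gives > 100000 nM in a functional assay on CCRF-CEM cells (Homo sapiens) for cytotoxicity, read by MTT assay, with a stated time of 72 h (a lower number here means a stronger inhibitor of growth, a higher number a weaker inhibitor of growth), and this is a limit of the assay rather than a number.
Compound 2 `COc1ccc(CNc2nc(SC)nc3ncccc23)cc1` gives > 100000 nM in this assay, which is likewise a limit and not a number.

Compound 1 therefore stands at the edge of what this assay can report: the limit of > 100000 nM in this assay, at which 2 of the 2 values shown sit. Among the measured compounds shown here, neither measured compound yields a number, and no pair of measured compounds differs in only one place, so there is no measured step from which the effect of a single change could be read. Compound 3 `CCCCC[Se]c1nc(N)c2ccccc2n1` differs from compound 1 by one nitrogen atom in place of a group of 6 heavy atoms (5 carbon, 1 selenium; no ring), on an aromatic carbon. With only limits to go on, the step from compound 1 to compound 3 is expected to be a step that the limit leaves unreadable from compound 1 to compound 3, meaning no change beyond the usual scatter is anticipated. Compound 3 is accordingly estimated at 120000 nM, with a range from 30000 nM to 400000 nM, and a limit rather than a number is the more likely outcome for compound 3.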

Compound 3, concentration for total growth inhibition: 68000 nM
Compound 3: middle estimate off by 1.8-fold (0.25 log units), on the high side, and the stated range covers the measured number.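

With an amino group in place of the group of 6 heavy atoms (5 carbon, 1 selenium; no ring), on an aromatic carbon, the shared core gives its first true number rather than a limit in this assay, and the change amounts to an at least 1.4-fold lower number from compound 1 to compound 3 (0.16 log units; that floor lies within the scatter). From the compounds shown here alone, that figure is only a floor, and the real size of the step stays unknown because compound 1 has no number of its own: the limit of > 100000 nM in this assay, at which 2 of the 3 values shown sit. What the result adds is therefore modest: the group at this position can be exchanged for amino and a readable value is obtained, but the floor alone does not establish a change beyond the usual scatter.

The compounds shown leave open how other groups at this position would behave, for example a methylamino group, a hydroxyl group or a shorter selenium-bearing chain, any of which could show whether the amino group itself matters. They also leave open what the remaining group of 6 heavy atoms contributes in compound 3, since no compound shown changes it while keeping the amino group.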